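The compounds below may be only part of what the source reports. "The series", "measured", "known", "first", "only" and "open" are said of these compounds alone.

Measured so far in a functional assay on A549 cells (Homo sapiens) for inhibition, read by sulforhodamine B assay, with a stated time of 48 h, tested at 10 uM; a lower number here means less inhibition, a higher number more inhibition at the concentration tested (going by the name of the read-out):
compound 1, `Brc1cn2ccnc2c(-c2ccc3ncn(C4CCCCC4)c3c2)n1`, gives 9.36%
compound 2, `COc1ccccc1-c1cn2ccnc2c(-c2ccc3ncn(C4CCCCC4)c3c2)n1`, gives 13.9%

Among the compounds with values here, compound 2 has the higher of the two numbers in this assay, but the one measured step, a number 4.5 percentage points higher from compound 1 to compound 2 (within the scatter), lies within the scatter, so compound 2 and compound 1 cannot be separated on these readings; both sit at low inhibition at the concentration tested.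

Compound 3, `FC(F)(F)c1cccc(-c2cn3ccnc3c(-c3ccc4ncn(C5CCCCC5)c4c3)n2)c1`, differs from compound 2 in one place: 3-(trifluoromethyl)phenyl in place of 2-methoxyphenyl on an aromatic carbon.

Within the data shown here, the only step that touches this position is a number 4.5 percentage points higher from compound 1 to compound 2 (within the scatter), which swapped bromo for 2-methoxyphenyl without a change beyond the scatter. Among the measured compounds shown here, no step between two aryl groups at this position has been measured, so the exchange of 2-methoxyphenyl for 3-(trifluoromethyl)phenyl rests on no direct precedent. Given that the one known change at this place stayed within the scatter, the step of a number 0.1 percentage points higher from compound 2 to compound 3 (within the scatter) is expected to stay within the scatter as well, with no direction beyond it.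

Compound 3 is therefore estimated at 14% in this assay, with a range from 3% to 28%.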

Compound 3, a percentage reported as inhibition, at one concentration (the size of the read-out at that concentration, not a potency): 5.15%
Compound 3: middle estimate off by 8.9 percentage points, on the high side, and the stated range covers the measured number.
By their numbers in this assay, from the lowest: compounds 3, 1 and 2 (each within the scatter of the next).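

In this assay this position now has a direct comparison between two aryl groups, and the exchange reads as a number 8.8 percentage points lower from compound 2 to compound 3 (within the scatter) with no separation of 3-(trifluoromethyl)phenyl from 2-methoxyphenyl. The direct exchange of bromo reads as a number 4.2 percentage points lower from compound 1 to compound 3 (within the scatter) and gives the same picture, so bromo and the two substituted phenyl groups cannot be told apart at this place on an aromatic carbon, and all three compounds stay at low inhibition at the concentration tested. This also means that neither the ring added to bromo's place nor the change from one hydrogen-bond acceptor to none in the entering group goes with a readable change here, and no outside data bear on these readings.

The compounds shown hold only bromo and substituted phenyl groups at this position, so the effect of an amine, a carboxylic acid or a longer chain there remains open. All three share the rest of the structure, which leaves open whether any change elsewhere on the shared core would lift the reading beyond the scatter.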